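Swapping a pyridine attachment point in a triaryl pyridine series

The compounds below may be only part of what the source reports. "The series", "measured", "known", "first", "only" and "open" are said of these compounds alone.

Compound 1 `c1ccc(-c2cc(-c3ccsc3)cc(-c3ccccn3)n2)nc1`: 0.0017 ug/mL
Compound 2 `c1ccc(-c2cc(-c3ccccn3)nc(-c3ccccn3)c2)cc1`: 0.017 ug/mL
Compound 3 `c1ccc(-c2cc(-c3cccs3)cc(-c3ccncc3)n2)nc1`: 0.22 ug/mL

In a functional assay on PC-3 cells (Homo sapiens) for antiproliferative activity (on this read-out higher numbers stand for weaker inhibition of growth and lower numbers for stronger inhibition of growth), compound 3 gives the highest number of the three, so the weakest growth inhibition. The change to compound 4 `c1ccc(-c2cc(-c3cccs3)cc(-c3ccccn3)n2)nc1` is pyridin-2-yl in place of pyridin-4-yl on an aromatic carbon. For the measured compounds named here, the only measured step, a 10-fold higher number from compound 1 to compound 2 (1.00 log units; beyond the scatter), concerns a different group and does not bear on this swap. Compound 4 would carry two pyridin-2-yl groups, as compound 1 and compound 2 do; in this assay compound 1 gives 0.0017 ug/mL and compound 2 gives 0.017 ug/mL. Because compound 1 gives 0.0017 ug/mL, compound 4 is expected to land well below compound 3, a step of a 44-fold lower number from compound 3 to compound 4 (1.64 log units; beyond the scatter). The estimate for compound 4 is 0.005 ug/mL, between 0.001 ug/mL and 0.03 ug/mL.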

Compound 4, concentration for 50% growth inhibition: 0.0021 ug/mL
Compound 4: middle estimate off by 2.4-fold (0.38 log units), on the high side; the measured number falls inside the stated range.
By their numbers in this assay, from the lowest: compounds 1 and 4 (each within the scatter of the next); then compound 2; then compound 3.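

In this assay, pyridin-2-yl and pyridin-4-yl have the same atoms, joined differently, yet this one change gives a 100-fold lower number from compound 3 to compound 4 (2.02 log units; beyond the scatter) at this position. With pyridin-2-yl in place, the neighbouring aromatic group also matters in part: thiophen-2-yl in place of phenyl gives an 8.1-fold lower number from compound 2 to compound 4 (0.91 log units; beyond the scatter) and thiophen-2-yl in place of thiophen-3-yl gives a 1.2-fold higher number from compound 1 to compound 4 (0.09 log units; within the scatter) with no real change. No measurement shown here explains the large pyridine step. Open, from the compounds shown here alone, is how pyridin-3-yl would behave at this position, and whether a non-aromatic group such as an amine or a carboxylic acid could take its place.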